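Swapping Dimethyl for Methoxy on a Thiourea Aryl Ring

A few compounds are considered here, and "the series" means these few. Any claim that something is new, unique, unknown or untested is made for them only; others in the source may bear on it.

Compound 2 `CNC(=O)c1ccc(Oc2cccc(NC(=S)Nc3ccc(C)c(C)c3)c2)nc1` is one of three thiourea analogues tested in a functional assay on MDA-MB-231 cells (Homo sapiens) for antiproliferative activity, read by MTT assay (a lower number here means a stronger inhibitor, a higher number a weaker inhibitor), where compound 2 gives 38600 nM. Among the three numbers compound 2 stands second highest. Its nearest neighbour is compound 1 `CNC(=O)c1ccc(Oc2cccc(NC(=S)Nc3ccc(Cl)cc3)c2)nc1`, which in this assay gives 66500 nM; the step of a 1.7-fold lower number from compound 1 to compound 2 (0.24 log units; within the scatter) keeps the two within the scatter. Far below both lies compound 3 `CNC(=O)c1ccc(Oc2cccc(NC(=S)Nc3ccc(Br)c(C(F)(F)F)c3)c2)nc1`, which in this assay gives 3020 nM. Compound 4 `CNC(=O)c1ccc(Oc2cccc(NC(=S)Nc3ccc(OC)cc3)c2)nc1` has not yet been measured. It differs from compound 2 in one place: 4-methoxyphenyl in place of 3,4-dimethylphenyl on an amide-type nitrogen. Among the compounds with values here, the only measured step that alters the same ring, a 1.7-fold lower number from compound 1 to compound 2 (0.24 log units; within the scatter), stayed within the scatter, so a further substituent swap on that ring gives little reason to expect a large shift. Within the data shown here, compound 3 shows that a much lower number is possible with a different group, but no single step links it to compound 2. For compound 4 the expected step is therefore a 1.3-fold higher number from compound 2 to compound 4 (0.11 log units; within the scatter), no change beyond the scatter. Compound 4 is estimated at 50000 nM, with a range from 15000 nM to 150000 nM.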

Compound 4, half-maximal inhibitory concentration: 31500 nM
Compound 4: middle estimate off by 1.6-fold (0.20 log units), on the high side; the measured number falls inside the stated range.
By their numbers in this assay, from the lowest: compound 3; then compounds 4, 2 and 1 (each within the scatter of the next, the first and the last beyond it).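

In this assay, the step to 4-methoxyphenyl on the amide-type nitrogen gives a 1.2-fold lower number from compound 2 to compound 4 (0.09 log units; within the scatter), so the hydrogen-bond acceptor counted in the entering group comes with no readable change from the 3,4-dimethylphenyl compound. Methoxy in place of chloro on an aromatic carbon gives a 2.1-fold lower number from compound 1 to compound 4 (0.32 log units; beyond the scatter), the first single-place change on this ring to pass the scatter, though only modestly. Nothing at hand offers a reason for either step.

As far as these compounds go, whether an amine or a longer chain such as ethoxy on that same aromatic carbon would move the number further remains open. From the compounds shown here alone, compound 3 carries bromo and trifluoromethyl together, so what each of these groups does alone also remains open.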